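Methoxy for Fluoro in a Growth Inhibition Series

This account rests on a few compounds, and the source may have more. Where it says the series, first, only, none or still open, it means among the compounds named here.

- Compound 1 (`O=C(/C(=C\c1ccccc1OCc1ccccc1)Sc1ccc(F)cc1)c1ccc(Cl)cc1`) gives 1000 nM
- Compound 2 (`O=C(O)c1ccc(C(=O)/C(=C\c2ccc(F)c([N+](=O)[O-])c2)SCc2ccc(C(F)(F)F)cc2)cc1`) gives 1000 nM

Two compounds have so far been examined in a functional assay on DU-145 cells (Homo sapiens) for inhibition, read by trypan blue exclusion, with a stated time of 96 h (a lower number here means a stronger inhibitor of growth, a higher number a weaker inhibitor of growth), and their values show no separation. Compound 1 stands at 1000 nM and so sits level with compound 2 within the scatter of repeated measurements. Together they give only a single level of growth inhibition and no trend.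

Compound 3 (`COc1ccc(S/C(=C/c2ccccc2OCc2ccccc2)C(=O)c2ccc(Cl)cc2)cc1`) has yet to be measured in this assay and differs from compound 1 in one place. Methoxy stands in place of fluoro on an aromatic carbon (methoxy in place of fluoro on an aromatic carbon) para to a large group, which turns the 4-fluorophenyl into 4-methoxyphenyl. For the measured compounds named here, no measured pair of compounds shows this change or any other single change, so the data give no direct guide to its size or direction. The best available anchor is compound 1 at 1000 nM and no shift beyond the scatter is expected in either direction. The expected change is the estimated step of no change at the digits printed from compound 1 to compound 3 (within the scatter) and it remains uncertain. Compound 3 is estimated to give 1000 nM (expected range 300 nM to 3000 nM).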

Compound 3, concentration for 50% growth inhibition: 1000 nM
Beside the measured number, compound 3's estimate shows no gap at the digits printed; the measured number falls inside the stated range.
By their numbers in this assay, from the lowest: compounds 1, 2 and 3 (each within the scatter of the next).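

In this assay, methoxy in place of fluoro on an aromatic carbon, para to a large group, gives no change at the digits printed from compound 1 to compound 3 (within the scatter). For the compounds shown here, this is the first single change that can be read, and it shows that 4-fluorophenyl and 4-methoxyphenyl cannot be told apart at this position in this read-out, even though the entering group has 2 heavy atoms where the leaving group has 1, and adds a hydrogen-bond acceptor. No measurement shown here offers a reason for this result.

Fluoro and methoxy are the only groups seen at this position, so it remains open whether an amine, a carboxylic acid or a longer chain such as butoxy on the same aromatic carbon would stay level with compound 1 at 1000 nM. Also open, on these data alone, is whether methoxy in place of fluoro would give the same result on a different core, such as that of compound 2.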